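This account rests on a few compounds, and the source may have more. Where it says the series, first, only, none or still open, it means among the compounds named here.

Measured compounds, with values in an assay on isolated protein for inhibition of leukotriene B4 receptor 1 (Homo sapiens); a lower number here means a stronger inhibitor, a higher number a weaker inhibitor:
- compound 1 `COc1cc(C(=O)O)ccc1Cc1cn(C(c2ccccc2)c2ccccc2)c2ccc([N+](=O)[O-])cc12`: in this assay compound 1 gives 500 nM
- compound 2 `COc1cc(C(=O)O)ccc1Cc1cn(C(c2ccccc2)c2ccccc2)c2ccc(Cl)cc12`: in this assay compound 2 gives 400 nM

The two measured compounds differ only at one aromatic carbon of the shared core. Among the measured compounds shown here, the step of a 1.3-fold lower number from compound 1 to compound 2 (0.10 log units; within the scatter) is small, so the two numbers sit within the scatter of each other and neither can be put ahead of the other; compound 2 stands at 400 nM, with compound 1 as its only neighbour.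

Compound 3 `COc1cc(C(=O)O)ccc1Cc1cn(C(c2ccccc2)c2ccccc2)c2ccc(Br)cc12` is the next member and has not been measured in this assay. It differs from compound 2 by bromo in place of chloro on an aromatic carbon. For the measured compounds named here, the one step on record, from the nitro of compound 1 to the chloro of compound 2, was within the scatter and is the only comparison bearing on this halogen exchange; nothing else speaks to a change of this kind. On that basis no step beyond the scatter is expected here, and the step from compound 2 to compound 3 is estimated at a 1.1-fold lower number from compound 2 to compound 3 (0.06 log units; within the scatter). For compound 3 the expected value in this assay is 350 nM, with a range from 150 nM to 900 nM.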

Compound 3, half-maximal inhibitory concentration: 400 nM
Beside the measured number, compound 3's estimate is 1.1-fold (0.06 log units) below it, and the stated range covers the measured number.
By their numbers in this assay, from the lowest: compounds 2, 3 and 1 (each within the scatter of the next).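

In this assay, among the compounds shown here, the exchange of chloro for bromo on this aromatic carbon gives no change at the digits printed from compound 2 to compound 3 (within the scatter), the first direct comparison of two halogens at this place. With the further comparison against nitro, a 1.3-fold lower number from compound 1 to compound 3 (0.10 log units; within the scatter), all three pairs among the nitro, chloro and bromo compounds now lie within the scatter, so the read-out does not separate these three groups on this carbon of the six-membered aromatic ring, where the earlier single step could speak for only two of them. No supporting information on record accounts for this lack of separation.

Going by these compounds, whether the same flat reading holds for an amine, a hydroxyl group or a longer alkyl chain on this carbon remains open, and a compound with plain hydrogen there would be needed to show whether a substituent at this place matters at all. Also open, on these data alone, is whether the three groups would still read alike with other changes on the shared core, since all the comparisons so far keep the rest of the structure fixed.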